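Adding a Methyl to the Short Acyl Chain

The compounds below may be only part of what the source reports. "The series", "measured", "known", "first", "only" and "open" are said of these compounds alone.

Measured compounds:
- Compound 1, `CC#CC(=O)N[C@@H]1[C@H]2OC(C)(C)O[C@H]2O[C@@H]1[C@H]1COC(C)(C)O1`, gives 500000 nM in a functional assay on K562 cells (Homo sapiens) for antiproliferative activity; on this read-out lower numbers stand for stronger inhibition and higher numbers for weaker inhibition.
- Compound 2, `CCCC(=O)N[C@@H]1[C@H]2OC(C)(C)O[C@H]2O[C@@H]1[C@H](O)CO`, gives 500000 nM in this assay.
- Compound 3, `CCCCCC(=O)N[C@@H]1[C@H]2OC(C)(C)O[C@H]2O[C@@H]1[C@H](O)CO`, gives 10000000 nM in this assay.

Compound 2 and compound 1 give numbers that do not differ at the digits shown, and both lie well apart from compound 3, which sits a 20-fold higher number from compound 2 to compound 3 (1.30 log units; beyond the scatter). Among the measured compounds shown here, that single step is the only measured change on the acyl chain, and it is large: growing the chain by ethyl in place of hydrogen on a saturated chain carbon, three bonds along the chain from a carbonyl carbon, weakened inhibition clearly.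

Compound 4, `CC(C)CC(=O)N[C@@H]1[C@H]2OC(C)(C)O[C@H]2O[C@@H]1[C@H](O)CO`, is not yet measured. It differs from compound 2 by methyl in place of hydrogen on a saturated chain carbon bound to two saturated chain carbons. The change adds one carbon at a different place than the step from compound 2 to compound 3, and it adds less, so the measured step gives only a rough guide. Because the only chain extension seen, a 20-fold higher number from compound 2 to compound 3 (1.30 log units; beyond the scatter), went toward weaker inhibition, a smaller move in the same direction is expected for compound 4 in this assay, namely a 3.0-fold higher number from compound 2 to compound 4 (0.48 log units; beyond the scatter). Compound 4 is therefore estimated at 1500000 nM, with a range from 500000 nM to 5000000 nM.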

Compound 4, half-maximal inhibitory concentration: 5000000 nM
Beside the measured number, compound 4's estimate is 3.3-fold (0.52 log units) below it; the measured number falls inside the stated range.
By their numbers in this assay, from the lowest: compounds 1 and 2 (each within the scatter of the next); then compounds 4 and 3 (each within the scatter of the next).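

A single methyl on the saturated chain carbon bound to two saturated chain carbons is enough to weaken inhibition in this assay, with a 10-fold higher number from compound 2 to compound 4 (1.00 log units; beyond the scatter). The loss of inhibition seen earlier therefore does not belong to the longer straight chain alone: the branched isobutylcarbonyl chain of compound 4 and the straight chain of compound 3 cannot be told apart, with a 2.0-fold lower number from compound 3 to compound 4 (0.30 log units; within the scatter), so in this small set, adding carbon to the propylcarbonyl chain has gone the same way both times, whether the chain branches or simply grows. Nothing in the data shown speaks to the reason for this loss.

From the compounds shown here alone, it remains open whether a shorter chain such as acetyl, or a chain carrying an amine or a carboxylic acid, would bring the number down from the level of compound 2 rather than push it up. Compound 1 differs from compound 2 in more than one place, so the matching numbers of those two say nothing about what its triple bond does on its own.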